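Series notes: from compound 2 to compound 4

The compounds below may be only part of what the source reports. "The series", "measured", "known", "first", "only" and "open" are said of these compounds alone.

Measured so far:
compound 1 `Cc1ccc(Nc2nc(C)c(C(=O)/C=C/c3ccc(Cl)cc3)s2)cc1` — > 25000 nM, a limit
compound 2 `COc1cc(/C=C/C(=O)c2sc(Nc3ccc(C)cc3)nc2C)cc(OC)c1OC` — > 25000 nM, a limit
compound 3 `COc1cccc(/C=C/C(=O)c2sc(Nc3ccccc3C)nc2C)c1` — > 25000 nM, a limit

In a functional assay on NCI-H460 cells (Homo sapiens) for cytotoxicity, read by MTT assay (on this read-out lower numbers stand for stronger inhibition and higher numbers for weaker inhibition), compound 2 gives only a limit, > 25000 nM, and no number. It stands at the limit of > 25000 nM in this assay, at which 3 of the 3 values shown sit, so nothing in the set separates it from the others. Compound 4 `COc1cc(/C=C/C(=O)c2sc(Nc3cccc(Cl)c3)nc2C)cc(OC)c1OC` differs from compound 2 in one place: 3-chlorophenyl in place of 4-methylphenyl on a nitrogen on an aromatic ring. The nitrogen carrying the change sits on an aromatic ring whose other neighbours are aromatic carbon. Among the measured compounds shown here, no measured pair shares this change, so no step size can be read off; with every value at the limit, no direction beyond the scatter is expected in this assay. Compound 4 is therefore expected near 30000 nM, between 8000 nM and 100000 nM, most likely again reported only as a limit. The step that the limit leaves unreadable from compound 2 to compound 4 implied by this estimate is expected to lie within the scatter.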

Compound 4, half-maximal inhibitory concentration: > 25000 nM
Compound 4 gave a limit, no number; the forecaster's own chance of this, stated with the estimate: 70%; the middle value lies beyond the limit too.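

Among the compounds shown here, compound 2 and compound 4 both stand only as limits in this assay, and no step between them can be read. The compounds shown leave open whether 3-chlorophenyl and 4-methylphenyl differ at all, since none has a numerical value.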